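This account rests on a few compounds, and the source may have more. Where it says the series, first, only, none or still open, it means among the compounds named here.

Among the three compounds measured in a functional assay on HEK293 cells for agonist activity at Bile acid receptor (Homo sapiens), read by a luciferase reporter (on this read-out lower numbers stand for an effect already at smaller amounts and higher numbers for an effect only at larger amounts of compound), compound 3 `CC(Nc1ccc(C(=O)O)cc1)c1ccc(OCc2c(-c3c(Cl)cccc3Cl)noc2C2CC2)nc1C(F)(F)F` gives 202 nM and stands at the highest number of the set. Compound 1 `CC(C)c1onc(-c2c(Cl)cccc2Cl)c1COc1ccc(N(C)Cc2cccc(C(=O)O)c2)c(C(F)(F)F)n1` gives 6 nM and compound 2 `CC(C)c1onc(-c2c(Cl)cccc2Cl)c1COc1ccc(N(C)Cc2ccc(C(=O)NS(C)(=O)=O)cc2)c(C(F)(F)F)n1` gives 11 nM in this assay, both well beyond the scatter from compound 3. Compound 4 `CC(Oc1ccc(C(=O)O)cc1)c1ccc(OCc2c(-c3c(Cl)cccc3Cl)noc2C2CC2)nc1C(F)(F)F` has not yet been measured. It differs from compound 3 only in one place: 4-carboxyphenoxy in place of (4-carboxyphenyl)amino on a saturated chain carbon bound to an aromatic carbon and a saturated chain carbon. Among the measured compounds shown here, no step between measured compounds covers this kind of exchange, so the expectation rests on compound 3 alone. A small step is expected, with no firm direction, from compound 3 to compound 4, a 1.5-fold higher number from compound 3 to compound 4 (0.17 log units; within the scatter). Compound 4 is therefore estimated at 300 nM, within a range of 80 nM to 1200 nM.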

Compound 4, half-maximal effective concentration: 611 nM
Estimate against measurement, compound 4: 2.0-fold (0.31 log units) below, within the range that was stated.
By their numbers in this assay, from the lowest: compounds 1 and 2 (each within the scatter of the next); then compound 3; then compound 4.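

In this assay, 4-carboxyphenoxy in place of (4-carboxyphenyl)amino on a saturated chain carbon bound to an aromatic carbon and a saturated chain carbon gives a 3.0-fold higher number from compound 3 to compound 4 (0.48 log units; beyond the scatter). Among the compounds shown here, this is the first sign that this position responds to the linking atom alone, since nitrogen gives way to oxygen while the carboxyphenyl part stays the same. What lies behind the change cannot be said from the data at hand. The compounds shown leave open how a sulfur or a methylene linking the same carboxyphenyl group would read.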